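Swapping the ester group of a pyridine-bearing lactone

The compounds below may be only part of what the source reports. "The series", "measured", "known", "first", "only" and "open" are said of these compounds alone.

Measured compounds:
- compound 1, `CCCC(CCC)C(=O)OCC1(CO)C/C(=C/c2ccncc2)C(=O)O1`: 44 nM
- compound 2, `CN(C)c1ccc(C(=O)OCC2(CO)C/C(=C\c3ccc4ccccc4n3)C(=O)O2)cc1`: 11 nM
- compound 3, `CCCC(CCC)C(=O)OCC1(CO)C/C(=C\c2cccnc2)C(=O)O1`: 1.6 nM

All three were tested in an assay on cells for displacement of a labelled ligand from Ras guanyl-releasing protein 3 (Homo sapiens); a higher number here means a weaker inhibitor, a lower number a stronger inhibitor. Compound 1 gives 44 nM, the highest number of the three, so it is the weakest inhibitor here. Compound 2 gives 11 nM, a lower number, and compound 3 gives 1.6 nM, lower still; both gaps lie beyond the usual scatter. Compound 2 and compound 3 each differ from compound 1 in more than one place, so their values show only the overall outcome, not the effect of any single change.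

Compound 4, `CN(C)c1ccc(C(=O)OCC2(CO)C/C(=C/c3ccncc3)C(=O)O2)cc1`, has not been measured. It differs from compound 1 in one place: 4-(dimethylamino)phenyl in place of 1-propylbutyl on a carbonyl carbon. The ester built on 4-(dimethylamino)phenyl is also present in compound 2, whose value 11 nM is the only hint available. Because compound 2 sits at 11 nM, a modest step toward a lower number is expected, estimated as a 1.8-fold lower number from compound 1 to compound 4 (0.25 log units; within the scatter), although a result within the scatter would not surprise. Compound 4 is therefore expected to give about 25 nM, in the range 6 nM to 100 nM.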

Compound 4, inhibition constant: 2360 nM
Beside the measured number, compound 4's estimate is 94-fold (1.97 log units) below it, outside the stated range (above it).
By their numbers in this assay, from the lowest: compound 3; then compound 2; then compound 1; then compound 4.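

In this assay, placing 4-(dimethylamino)phenyl instead of 1-propylbutyl on this carbonyl carbon gives a 54-fold higher number from compound 1 to compound 4 (1.73 log units; beyond the scatter), so the group at this position can strongly change the result when the rest of the molecule stays the same. Among the compounds shown here, this is the first comparison here that isolates a single change, and it shows that the ester shared by compound 2 and compound 4 does not bring a low number on its own. Nothing available explains why this swap weakens the compound so sharply.

As far as these compounds go, it remains open whether the loss comes from the aromatic ring or from its dimethylamino group, a question that a plain phenyl or a cyclohexyl group on the same core could help to answer. Also open, from the compounds shown here alone, is whether the same swap would have a similar effect on the core of compound 3.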